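Pyridin-2-yl for phenyl on a shared core

The source may report more compounds than this note shows. Statements on the series, on what has been measured and on what is new or still open speak of the compounds shown alone.

Compound 3 `Nc1c2c(=O)[nH]c(-c3ccccc3)cc2nn1-c1ccccc1` gives -8% in an assay on isolated protein for inhibition of serine/threonine-protein kinase Chk2 (Homo sapiens), read by mobility shift assay, tested at 30 uM (on this read-out lower numbers stand for less inhibition and higher numbers for more inhibition at the one concentration tested (going by the name of the read-out)), the lowest of the three numbers at hand. Compound 1 `Cc1cc2nn(-c3ccccc3)c(N)c2c(=O)[nH]1` gives -4% in this assay and compound 2 `CC(C)(C)c1cc2nn(-c3ccccc3)c(N)c2c(=O)[nH]1` gives 5%; the step of a number 4 percentage points lower from compound 1 to compound 3 (within the scatter) lies within the scatter, while a number 13 percentage points lower from compound 2 to compound 3 (beyond the scatter) reaches beyond it. Compound 4 `Nc1c2c(=O)[nH]c(-c3ccccn3)cc2nn1-c1ccccc1` differs from compound 3 by pyridin-2-yl in place of phenyl on an aromatic carbon. Among the measured compounds shown here, no measured step makes this kind of exchange, so the two steps at this position, a number 4 percentage points lower from compound 1 to compound 3 (within the scatter) and a number 13 percentage points lower from compound 2 to compound 3 (beyond the scatter), are the only guide, and all three numbers sit near zero. Compound 4 is therefore expected to stay at this level, with a step of a number 4 percentage points higher from compound 3 to compound 4 (within the scatter) that is not beyond the scatter. The estimated value of compound 4 is -4%, within -20% to 12%.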

Compound 4, a percentage reported as inhibition, at one concentration (the size of the read-out at that concentration, not a potency): 3%
For compound 4 the middle estimate is 7 percentage points below the measured one; low and high end bracket the measured number.
By their numbers in this assay, from the lowest: compounds 3, 1, 4 and 2 (each within the scatter of the next, the first and the last beyond it).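

In this assay, pyridin-2-yl for phenyl gives a number 11 percentage points higher from compound 3 to compound 4 (beyond the scatter), so a ring nitrogen in place of a ring carbon is enough to separate these two aromatic groups at this position, though only close to zero. Against the alkyl groups no such separation appears: a number 2 percentage points lower from compound 2 to compound 4 (within the scatter), and a number 7 percentage points higher from compound 1 to compound 4 (within the scatter). Nothing available accounts for the step from phenyl to pyridin-2-yl.

On these data alone, whether the position of the ring nitrogen matters stays open, as pyridin-3-yl and pyridin-4-yl do not appear here. So does whether a group such as an amine or a carboxylic acid at this position would give clear inhibition in this assay.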